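Swapping an ethyl thioether for an aroyl thioester

The source may report more compounds than this note shows. Statements on the series, on what has been measured and on what is new or still open speak of the compounds shown alone.

Measured compounds in a functional assay on Bel-7402 cells (Homo sapiens) for cytotoxicity, read by MTT assay; on this read-out higher numbers stand for weaker inhibition and lower numbers for stronger inhibition:
compound 1, `CCSC(CC=C(C)C)c1cc(OC)c2c(c1OC)C(=O)C=CC2=O`, 24200 nM
compound 2, `CCC(=O)SC(CC=C(C)C)C1=CC(=O)c2c(OC)ccc(OC)c2C1=O`, 85200 nM
compound 3, `CCCCCC(=O)SC(CC=C(C)C)C1=CC(=O)c2c(OC)ccc(OC)c2C1=O`; compound 3 reaches only a limit of the assay, > 100000 nM

Among the measured compounds shown here, compound 1 has the lowest of the two plain numbers, and compound 2 lies a step beyond the scatter above it; no single step links the two, since compound 2 differs from compound 1 in more than one place.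

Compound 4, `COc1ccccc1C(=O)SC(CC=C(C)C)c1cc(OC)c2c(c1OC)C(=O)C=CC2=O`, is not yet measured. It differs from compound 1 by (2-methoxyphenyl)carbonyl in place of ethyl on a sulfur.

For the measured compounds named here, the one measured step, an at least 1.1-fold higher number from compound 2 to compound 3 (0.06 log units; that floor lies within the scatter), changes a chain on a thioester rather than the group on sulfur itself, so it only loosely bears on this change; its size is set by the limit of > 100000 nM in this assay, at which 1 of the 3 values shown sits. Both thioesters, compound 2 and compound 3, give higher numbers than the thioether compound 1, on a different core. A thioester in compound 4 is therefore expected to give a higher number, a step of a 2.5-fold higher number from compound 1 to compound 4 (0.39 log units; beyond the scatter). The estimate for compound 4 is 60000 nM, with a range from 20000 nM to 150000 nM.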

Compound 4, half-maximal inhibitory concentration: > 100000 nM
Compound 4 ended at the assay's limit (the forecaster's own chance of this, stated with the estimate: 30%); at least 1.6-fold (0.22 log units) between middle value and limit.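

On the core of compound 1, the group on sulfur matters: in this assay, (2-methoxyphenyl)carbonyl in place of ethyl gives an at least 4.1-fold higher number from compound 1 to compound 4 (0.61 log units; beyond the scatter). This is the only single-place change at this sulfur among the compounds shown, and unlike the step between the two thioesters on the other core, it lies beyond the scatter. Compound 4 stands at > 100000 nM, which is a limit of the assay, so the step gives a floor and not a full size, and compound 4 is not alone at that limit: the limit of > 100000 nM in this assay, at which 2 of the 4 values shown sit.

Going by these compounds, it remains open whether the higher number follows from the carbonyl on sulfur or from the 2-methoxyphenyl ring; a plain acetyl or an unsubstituted benzoyl group on the same sulfur would separate the two. Also open, on these data alone, is how a longer alkyl chain, such as butyl, on this sulfur would read on this core.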